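A few compounds are considered here, and "the series" means these few. Any claim that something is new, unique, unknown or untested is made for them only; others in the source may bear on it.

Measured so far in a functional assay on CHO cells with adenosine receptor A1 (Homo sapiens) as the target, read by cAMP accumulation and immunoassay, with a stated time of 6 min, tested at 10 uM; a lower number here means a stronger effect, a higher number a weaker effect of the compound at the concentration tested:
Compound 1, `Nc1scc(CN2CCN(c3cc(Cl)cc(Cl)c3)CC2)c1C(=O)c1ccc(Cl)cc1`, gives -74%.
Compound 2, `Nc1scc(CN2CCN(c3ccccc3C(F)(F)F)CC2)c1C(=O)c1ccc(Cl)cc1`, gives -60%.
Compound 3, `Nc1scc(CN2CCN(c3cccc(F)c3)CC2)c1C(=O)c1ccc(Cl)cc1`, gives -82%.

All three share one core and differ only in the aromatic group on an amine nitrogen in a ring. Compound 3 has the lowest number of the three shown; its nearest neighbour is compound 1, whose number is higher but within the scatter, and its furthest is compound 2, whose number is higher by an amount beyond the scatter.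

Compound 4, `Nc1scc(CN2CCN(c3ccc(F)cc3F)CC2)c1C(=O)c1ccc(Cl)cc1`, has not yet been measured. It differs from compound 3 in one place: 2,4-difluorophenyl in place of 3-fluorophenyl on an amine nitrogen in a ring.

Among the compounds with values here, two measured steps bear on this change. Both also swap the aromatic group on that ring nitrogen: a number 8 percentage points lower from compound 1 to compound 3 (within the scatter) and a number 22 percentage points lower from compound 2 to compound 3 (beyond the scatter). These show that exchanging one halogenated phenyl for another moves the number in this assay only modestly, and in one case not beyond the scatter. Exchanging 3-fluorophenyl for 2,4-difluorophenyl is a change of the same kind, so no step beyond the scatter is expected, though a slight rise is possible. Compound 4 is therefore estimated at -75% in this assay, between -92% and -55%, which means an expected step of a number 7 percentage points higher from compound 3 to compound 4 (within the scatter).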

Compound 4, a percentage reported as activity, at one concentration (the size of the read-out at that concentration, not a potency): -82%
Compound 4: middle estimate off by 7 percentage points, on the high side; low and high end bracket the measured number.
By their numbers in this assay, from the lowest: compounds 3, 4 and 1 (each within the scatter of the next); then compound 2.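

In this assay, going from 3-fluorophenyl to 2,4-difluorophenyl on the ring nitrogen adds a second fluorine and gives no change at the digits printed from compound 3 to compound 4 (within the scatter), so this position takes that change without a step that can be told from the scatter. Within the data shown here, the other two new steps are a number 8 percentage points lower from compound 1 to compound 4 (within the scatter) and a number 22 percentage points lower from compound 2 to compound 4 (beyond the scatter), which leaves the 2-(trifluoromethyl)phenyl group of compound 2 as the only one of the four groups set apart by steps beyond the scatter. Nothing among the data shown explains why these groups read as they do.

From the compounds shown here alone, all four groups are phenyl rings bearing halogen atoms or trifluoromethyl, so it stays open whether a phenyl ring carrying a methoxy group or an amine would read the same in this assay. Each reading also comes from a single concentration, so the compounds that cannot be told apart here could still differ in potency.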